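The source may hold more compounds than are shown below. What is called first, only, known or untested is meant among the compounds shown, and "the series" means these compounds.

Compound 3 `Cc1oc(C(=O)NS(=O)(=O)c2ccccc2)cc1COc1ccc(-c2ccc(OC(F)F)cc2)cc1` is the starting point here. In an assay on cells for displacement of a labelled ligand from prostaglandin E2 receptor EP4 subtype (Homo sapiens), read by scintillation counting (on this read-out lower numbers stand for stronger inhibition and higher numbers for weaker inhibition), compound 3 gives 1.3 nM. Within the data shown here, of the two numbers measured so far this is the higher one; its nearest neighbour is compound 2 `Cc1noc(C)c1S(=O)(=O)NC(=O)c1cc(COc2ccc(-c3ccc(OC(F)F)cc3)cc2)c(C)o1`, which in this assay gives 0.6 nM. Among the measured compounds shown here, the single measured step, a 2.2-fold higher number from compound 2 to compound 3 (0.34 log units; beyond the scatter), is modest yet lies beyond the scatter. Compound 1 `Cc1oc(C(=O)O)cc1COc1ccc(-c2ccncc2)cc1` in this assay gives > 10000 nM, which is a limit of the assay rather than a number. The next compound, compound 4 `CC(=O)c1ccc(-c2ccc(OCc3cc(C(=O)NS(=O)(=O)c4ccccc4)oc3C)cc2)cc1`, differs from compound 3 in one place: acetyl in place of difluoromethoxy on an aromatic carbon. For the measured compounds named here, no measured step touches that part of the structure; the only step known, a 2.2-fold higher number from compound 2 to compound 3 (0.34 log units; beyond the scatter), alters the group on the sulfonyl sulfur instead. There is thus no direct measured guide for this change, and a step of roughly the size already seen, in either direction, is the most that can be foreseen. Compound 4 is therefore expected to give 2 nM in this assay, between 0.6 nM and 8 nM. This amounts to an expected step of a 1.5-fold higher number from compound 3 to compound 4 (0.19 log units; within the scatter).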

Compound 4, inhibition constant: 20 nM
The estimate for compound 4 lay 10-fold (1.00 log units) below the measured number; measured number outside the range, above it.
By their numbers in this assay, from the lowest: compound 2; then compound 3; then compound 4. At a limit, above all of these: compound 1.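

This position on the six-membered aromatic ring, para to a large group, is sensitive to what sits on it. In this assay, acetyl in place of difluoromethoxy gives a 15-fold higher number from compound 3 to compound 4 (1.19 log units; beyond the scatter) and this is a much larger step than the change on the sulfonyl sulfur, a 2.2-fold higher number from compound 2 to compound 3 (0.34 log units; beyond the scatter) and yet both groups count one hydrogen-bond acceptor and no net charge, so those counts do not separate them. Nothing measured here accounts for the size of this step.

As far as these compounds go, it remains open whether a methoxy, a nitrile, an amine or a carboxylic acid at this position would fall nearer to compound 3 or to compound 4. From the compounds shown here alone, it is also open whether acetyl would cost as much alongside the 3,5-dimethyl-1,2-oxazol-4-yl group of compound 2.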